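Ortho phenyl on the aryl ether of compound 2

A few compounds are considered here, and "the series" means these few. Any claim that something is new, unique, unknown or untested is made for them only; others in the source may bear on it.

In a functional assay on cells for agonist activity at Free fatty acid receptor 1 (Mus musculus), read by FLIPR and calcium flux, with a stated time of 100 s (a higher number here means that more compound is needed for the effect, a lower number that less compound is needed), compound 1 `Cc1ccccc1COc1ccc(N2CCC[C@H]2CC(=O)O)cc1` gives 3400 nM. Compound 2 `O=C(O)C[C@@H]1CCCN1c1ccc(Oc2ccccc2)cc1` reaches only a limit in this assay, > 16000 nM, so its number is not known exactly. This is the limit of > 16000 nM in this assay, at which 1 of the 2 values shown sits, which puts compound 2 at the weak end of the two values shown. For the measured compounds named here, the step of an at least 4.7-fold higher number from compound 1 to compound 2 (0.67 log units; beyond the scatter) is the only measured step that bears on the ether substituent. Compound 3 `O=C(O)C[C@@H]1CCCN1c1ccc(Oc2ccccc2-c2ccccc2)cc1` differs from compound 2 by phenyl in place of hydrogen on an aromatic carbon. A return toward a lower number is expected, of modest size and uncertain from a limit. Compound 3 is therefore estimated at 8000 nM (range 2500 nM to 25000 nM). The expected step is an at least 2.0-fold lower number from compound 2 to compound 3 (0.30 log units; that floor lies within the scatter).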

Compound 3, half-maximal effective concentration: 1300 nM
Estimate against measurement, compound 3: 6.2-fold (0.79 log units) above, outside the stated range (below it).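

The ortho position on the phenyl ether of compound 2 responds strongly to substitution: phenyl in place of hydrogen gives an at least 12-fold lower number from compound 2 to compound 3 (1.09 log units; beyond the scatter). Compound 2 is therefore not a dead end for this ether, since one added ring restores a measurable response, with compound 3 at 1300 nM. That step is only a floor, as one end of it is a limit: the limit of > 16000 nM in this assay, at which 1 of the 3 values shown sits.

From the compounds shown here alone, it remains open whether methyl or methoxy at this place would serve as well as phenyl. Also open, going by these compounds, is whether a pyridine ring could replace the added phenyl.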